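This account rests on a few compounds, and the source may have more. Where it says the series, first, only, none or still open, it means among the compounds named here.

The series rests on a shared core carrying a ribose-like sugar, as seen in compound 1 `OC[C@H]1OC(n2cnc3c(Nc4ccccc4)nccc32)[C@H](O)[C@@H]1O`, which in a functional assay (Homo sapiens) for inhibition of Nucleic Acid, tested at 100 uM (on this read-out lower numbers stand for less inhibition and higher numbers for more inhibition at the one concentration tested (going by the name of the read-out)), gives 4%. Compound 2 `CCNc1nccc2c1ncn2C1O[C@H](CO)[C@@H](O)[C@H]1O` keeps that core and in this assay gives 4%. Going by the values given here, the one recorded step, no change at the digits printed from compound 1 to compound 2 (within the scatter), involved an ethyl in place of phenyl on a nitrogen on an aromatic ring. On these numbers compound 2 stands level with compound 1, both showing essentially no inhibition at the single concentration tested.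

Compound 3 `OC[C@H]1OC(n2cnc3c(Cl)nccc32)[C@H](O)[C@@H]1O` is next. Relative to compound 2 the change is chloro in place of ethylamino on an aromatic carbon. Among the compounds with values here, no recorded step swaps ethylamino for chloro, so the only guide is the earlier step, which itself fell within the scatter despite a sizeable change at the same ring nitrogen substituent. Both measured compounds sit near the floor of the read-out, so there is little room for any decrease, and nothing in hand points to a rise beyond the scatter. The expected step from compound 2 to compound 3 is therefore a number 1 percentage points higher from compound 2 to compound 3 (within the scatter), and compound 3 is estimated in this assay at 5%, with a range from -5% to 18%.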

Compound 3, a percentage reported as inhibition, at one concentration (the size of the read-out at that concentration, not a potency): 76%
Beside the measured number, compound 3's estimate is 71 percentage points below it; the whole stated range lies below it.
By their numbers in this assay, from the lowest: compounds 1 and 2 (each within the scatter of the next); then compound 3.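

Chloro in place of ethylamino on an aromatic carbon gave a number 72 percentage points higher from compound 2 to compound 3 (beyond the scatter) in this assay, and chloro in place of anilino at the same carbon, next to the ring nitrogen, gave a number 72 percentage points higher from compound 1 to compound 3 (beyond the scatter). Going by these compounds alone, the earlier step had compared only two groups joined through nitrogen and found nothing to separate them, so it could have suggested that this position hardly matters; the two new steps show that the read-out at the one concentration tested can respond strongly to the group on this carbon. Nothing available explains why chloro stands so far from ethylamino and anilino here.

The compounds shown leave open whether the rise belongs to chloro itself or follows from the removal of a nitrogen-linked group, a question that bromo, methoxy, a methyl group or a plain hydrogen on this carbon would help to separate. They also leave open how an unsubstituted amine would read here, and how compound 3 would behave across a range of concentrations, since a single-concentration percentage is not a potency.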